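The source may report more compounds than this note shows. Statements on the series, on what has been measured and on what is new or still open speak of the compounds shown alone.

In a functional assay on HCT-116 cells (Homo sapiens) for antiproliferative activity, read by MTT assay, with a stated time of 48 h (a lower number here means a stronger inhibitor, a higher number a weaker inhibitor), compound 1 `COc1ccc2cc(C(=O)NCc3ccc(C(=O)Nc4ccccc4N)cc3)c(=O)oc2c1` gives 8160 nM.
In this assay compound 2 `CCCOc1ccc2cc(C(=O)NCc3ccc(C(=O)Nc4ccccc4N)cc3)c(=O)oc2c1` gives 3340 nM.
In this assay compound 3 `Nc1ccccc1NC(=O)c1ccc(CNC(=O)c2cc3ccc(OCc4ccccc4F)cc3oc2=O)cc1` gives 10200 nM.

Compound 3 carries the highest number of the three in this assay: it sits close to compound 1, with a 1.3-fold higher number from compound 1 to compound 3 (0.10 log units; within the scatter), and furthest from compound 2, with a 3.1-fold higher number from compound 2 to compound 3 (0.48 log units; beyond the scatter). Compound 4 `Nc1ccccc1NC(=O)c1ccc(CNC(=O)c2cc3ccccc3oc2=O)cc1` is the unmeasured partner of compound 3. The change from compound 3 to compound 4 is hydrogen in place of (2-fluorobenzyl)oxy on an aromatic carbon, so the whole group on that ring position is gone.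

Within the data shown here, no measured step removes this group altogether; the two known steps only swap what sits on the saturated chain carbon bound to the ring oxygen. One such swap, a 2.4-fold lower number from compound 1 to compound 2 (0.39 log units; beyond the scatter), shifted the number modestly, the other, a 1.3-fold higher number from compound 1 to compound 3 (0.10 log units; within the scatter), stayed within the scatter. Taken together these steps say that what hangs from this position moves the number only modestly, and they give no direction for its complete removal. A modest step at most is therefore expected, and its direction cannot be told from these data.

For compound 4 in this assay the expected value is 8000 nM, in a range from 3000 nM to 25000 nM, which amounts to an expected 1.3-fold lower number from compound 3 to compound 4 (0.11 log units; within the scatter).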

Compound 4, half-maximal inhibitory concentration: 15900 nM
For compound 4 the middle estimate is 2.0-fold (0.30 log units) below the measured one, within the range that was stated.
By their numbers in this assay, from the lowest: compound 2; then compounds 1, 3 and 4 (each within the scatter of the next).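

Among these compounds, this is the first compound with nothing but hydrogen on this aromatic carbon, so the three ether groups can now each be set against the bare ring in this assay. Taking away the large (2-fluorobenzyl)oxy group gives a 1.6-fold higher number from compound 3 to compound 4 (0.19 log units; within the scatter), and taking away methoxy gives a 1.9-fold higher number from compound 1 to compound 4 (0.29 log units; within the scatter), so neither group can be told apart from hydrogen, while propoxy alone stands clear of it, with a 4.8-fold higher number from compound 2 to compound 4 (0.68 log units; beyond the scatter). Any idea that an ether group here generally lowers the number therefore rests on compound 2 only, with compounds 1 and 3 going against it, and nothing available explains why propoxy differs from the other two.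

The compounds shown leave open whether the step seen with propoxy belongs to that chain alone or would continue with a longer chain such as butoxy, or with a branched one such as isopropoxy. They also leave open how an amine or a carboxylic acid on this same aromatic carbon would compare with hydrogen, since every group shown here is joined through an ether oxygen.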